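The source may report more compounds than this note shows. Statements on the series, on what has been measured and on what is new or still open speak of the compounds shown alone.

Working notes on the series.

Compound 1 `O=C(NO)c1cnc(N2CCN(S(=O)(=O)c3ccc4ccccc4c3)CC2)s1` and compound 2 `O=C(NO)c1cnc(N2CCN(S(=O)(=O)c3ccc(OC(F)(F)F)cc3)CC2)s1` differ in the aryl part of the sulfonyl group; the difference between the two cores is not broken down here. In a functional assay on MCF7 cells (Homo sapiens) for antiproliferative activity (a higher number here means a weaker inhibitor of growth, a lower number a stronger inhibitor of growth), compound 1 gives 2000 nM, and compound 2 gives 4000 nM; these two values lie within the scatter of each other.

Compound 3 `O=C(/C=C/c1cnc(N2CCN(S(=O)(=O)c3ccc4ccccc4c3)CC2)s1)NO` carries one change on the core of compound 1, (2-(hydroxycarbamoyl)ethenyl in place of hydroxycarbamoyl on an aromatic carbon), and the step was a 2.9-fold lower number from compound 1 to compound 3 (0.46 log units; beyond the scatter). In this assay compound 3 gives 700 nM.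

Compound 4 `O=C(/C=C/c1cnc(N2CCN(S(=O)(=O)c3ccc(OC(F)(F)F)cc3)CC2)s1)NO` carries the same change on the core of compound 2, (2-(hydroxycarbamoyl)ethenyl in place of hydroxycarbamoyl on an aromatic carbon); the surroundings of the place are the same in both pairs.

For the measured compounds named here, for compound 4 the expected step in this assay is a 2.9-fold lower number from compound 2 to compound 4 (0.46 log units; beyond the scatter), resting on the single precedent a 2.9-fold lower number from compound 1 to compound 3 (0.46 log units; beyond the scatter). Compound 4 is therefore estimated at 1400 nM, between 600 nM and 3500 nM.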

Compound 4, concentration for 50% growth inhibition: 6000 nM
Beside the measured number, compound 4's estimate is 4.3-fold (0.63 log units) below it, and the stated range ends below it.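

In this assay, the change to 2-(hydroxycarbamoyl)ethenyl does not carry over from one core to the other with the same size: the same change on two cores in this assay, a 2.9-fold lower number (0.46 log units; beyond the scatter) from compound 1 to compound 3 and a 1.5-fold higher number (0.18 log units; within the scatter) from compound 2 to compound 4, 4.3-fold (0.63 log units) apart, beyond the scatter of two such steps. On the core of compound 2 the step is a 1.5-fold higher number from compound 2 to compound 4 (0.18 log units; within the scatter), so the lower number seen on the core of compound 1 does not recur there. For the compounds shown here, with one pair per core, this shows only that the step depends on the core in these two cases; it does not show which feature of the aryl part decides the outcome, nor how other cores would respond.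

On these data alone, a longer chain ending in hydroxycarbamoyl remains open on either core. So does the same change with a methoxy or nitrile group on the aryl part of the sulfonyl group.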